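The source may hold more compounds than are shown below. What is called first, only, known or untested is meant among the compounds shown, and "the series" means these compounds.

Three related compounds have been measured in a functional assay on HepG2 cells (Homo sapiens) for inhibition, read by fluorescence and resazurin assay, with a stated time of 72 h; on this read-out higher numbers stand for weaker inhibition and lower numbers for stronger inhibition. Compound 1 `O=C(Nc1ccccc1)Nc1cccc(Nc2nccc(Nc3ccc4nc[nH]c4c3)n2)c1` gives 11000 nM, and compound 3 `COc1ccc(NC(=O)Nc2ccccc2)cc1Nc1nccc(Nc2ccc3cn[nH]c3c2)n1` gives 6500 nM; these two values lie within the usual scatter of each other. Compound 2 `O=C(Nc1ccc(F)cc1)Nc1ccc(Nc2nccc(Nc3ccc4cn[nH]c4c3)n2)cc1` gives 3500 nM, a clearly lower number than that of compound 1. Compound 1 therefore shares the upper end of the range with compound 3, the weaker side on this read-out.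

Compound 4 `O=C(Nc1ccccc1)Nc1cccc(Nc2nccc(Nc3ccc4[nH]ccc4c3)n2)c1` keeps the rest of compound 1 and changes one group: 1H-indol-5-yl in place of 1H-benzimidazol-6-yl on a nitrogen on an aromatic ring. In words, 1H-indol-5-yl stands in place of 1H-benzimidazol-6-yl on a nitrogen on an aromatic ring. For the measured compounds named here, no measured pair isolates a change of this kind, so its size can only be judged loosely. The measured values span little, from compound 2 at 3500 nM to compound 1 at 11000 nM, so only a small step is expected, with a slight lean towards a lower number and none beyond the scatter. The estimated change is a 1.8-fold lower number from compound 1 to compound 4 (0.26 log units; within the scatter). For compound 4 the expected value is 6000 nM, with an estimated range of 2000 nM to 18000 nM.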

Compound 4, half-maximal inhibitory concentration: 5000 nM
The estimate for compound 4 lay 1.2-fold (0.08 log units) above the measured number; measured number inside the range.
By their numbers in this assay, from the lowest: compounds 2, 4, 3 and 1 (each within the scatter of the next, the first and the last beyond it).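

Replacing 1H-benzimidazol-6-yl with 1H-indol-5-yl on the nitrogen gives a 2.2-fold lower number from compound 1 to compound 4 (0.34 log units; beyond the scatter) in this assay, and this is the only pair shown that differs in one place. It shows that the number at this position responds to the group attached there, although the step is modest and lies only just beyond the usual scatter. The entering group has 1 nitrogen and 0 hydrogen-bond acceptors, against 2 nitrogens and 1 acceptor in the leaving group, but no measurement here explains the lower number.

On these data alone, it remains open whether the same replacement would give a similar step on compound 2 or compound 3. As far as these compounds go, it is also open how a plain phenyl ring, or a phenyl ring carrying an amine or a carboxylic acid, would read on this nitrogen.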